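This account rests on a few compounds, and the source may have more. Where it says the series, first, only, none or still open, it means among the compounds named here.

Of the compounds shown here, three from one series have been tested in a functional assay on CHO-K1 cells for antagonist activity at C-X-C chemokine receptor type 3 (Homo sapiens), read by FLIPR, with a stated time of 10 min, in the presence of a further agent that is not named here; a lower number here means a stronger inhibitor, a higher number a weaker inhibitor. Compound 1, with the structure `C[C@@H]1CN(c2sc(C(F)(F)F)nc2-c2nc3ccccc3[nH]2)CCN1C(=O)Cn1cnc2c1CCN(C)C2`, gives 3.6 nM, the lowest of the three numbers. Compound 2, `C[C@@H]1CN(c2sc(C(F)(F)F)nc2-c2nc3ccc(CO)cc3[nH]2)CCN1C(=O)Cn1cnc2cccnc21`, gives 4.6 nM; its number and that of compound 1 lie within the scatter of each other, so no order between them can be read. Compound 3, `Cc1nc(C)n(CC(=O)N2CCN(c3sc(C(F)(F)F)nc3-c3nc4ccc(S(C)(=O)=O)cc4[nH]3)C[C@H]2C)n1`, gives 10 nM, a gap from compound 1 that lies beyond the scatter.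

Compound 4, `C[C@@H]1CN(c2sc(C(F)(F)F)nc2-c2nc3ccccc3[nH]2)CCN1C(=O)CN1C(=O)OC[C@@H]1c1ccccc1`, has not yet been measured in this assay. Relative to compound 1 it carries a group of 12 heavy atoms (9 carbon, 1 nitrogen, 2 oxygen; one five-membered non-aromatic ring with 2 hetero atoms, one six-membered aromatic ring of carbon only) in place of a group of 10 heavy atoms (7 carbon, 3 nitrogen; one five-membered aromatic ring with 2 hetero atoms, one six-membered non-aromatic ring with 1 hetero atom), on a saturated chain carbon bound to a carbonyl carbon. The three measured compounds differ from one another at this same saturated chain carbon and at the shared core, and their numbers stay close; this suggests the change in compound 4 is tolerated, though only three points support that view. The step from compound 1 to compound 4 is expected to be a 2.2-fold higher number from compound 1 to compound 4 (0.35 log units; beyond the scatter), a small move toward a higher number, near the edge of the scatter. Compound 4 is therefore estimated at 8 nM, in a range from 2 nM to 40 nM.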

Compound 4, half-maximal inhibitory concentration: 360 nM
Compound 4: middle estimate off by 45-fold (1.65 log units), on the low side; the whole stated range lies below it.
By their numbers in this assay, from the lowest: compounds 1 and 2 (each within the scatter of the next); then compound 3; then compound 4.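

Placing 2-oxo-4-phenyl-1,3-oxazolidin-3-yl on the saturated chain carbon bound to a carbonyl carbon, in place of the group of compound 1, gives a 100-fold higher number from compound 1 to compound 4 (2.00 log units; beyond the scatter) in this assay. For the compounds shown here, this is the first step with a single point of difference, and it shows that this position does not accept every group: the close numbers of the earlier compounds, which also differ at the shared core, had not revealed this. Nothing available explains the size of this loss.

The exchange replaces both rings of the group at once, so the compounds shown do not separate the contribution of the phenyl ring from that of the ring carrying it. As far as these compounds go, how a plain phenyl or an unsubstituted 2-oxo-1,3-oxazolidin-3-yl would behave at this carbon remains open.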